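Extending the saturated chain from compound 2 to compound 3

A few compounds are considered here, and "the series" means these few. Any claim that something is new, unique, unknown or untested is made for them only; others in the source may bear on it.

In a functional assay on HaCaT cells (Homo sapiens) for inhibition, read by MTT assay, with a stated time of 72 h (on this read-out lower numbers stand for stronger inhibition and higher numbers for weaker inhibition), compound 1 (`O=C(CCN=C=S)Nc1ccc2ncnc(Nc3cccc(Br)c3)c2c1`) gives 18900 nM and compound 2 (`O=C(CCCN=C=S)Nc1ccc2ncnc(Nc3cccc(Br)c3)c2c1`) gives 16300 nM. Within the data shown here, these two numbers lie within the scatter of each other, so compound 2 stands level with the only other measured compound and the pair cannot be ranked.

Compound 3 (`O=C(CCCCN=C=S)Nc1ccc2ncnc(Nc3cccc(Br)c3)c2c1`) has not yet been measured. Its difference from compound 2 is this: a group of 4 heavy atoms (2 carbon, 1 nitrogen, 1 sulfur; no ring) in place of a group of 3 heavy atoms (1 carbon, 1 nitrogen, 1 sulfur; no ring), on a saturated chain carbon, three bonds along the chain from a carbonyl carbon.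

Among the measured compounds shown here, only one measured step bears on this change: a 1.2-fold lower number from compound 1 to compound 2 (0.06 log units; within the scatter). It is the same kind of replacement, made on a saturated chain carbon two bonds along the chain from a carbonyl carbon, whereas the new one lies three bonds along. That step stays within the scatter, but a single step is thin evidence and says nothing about longer chains. On this basis, no step beyond the scatter is expected in this assay, and no direction can be assigned. The expected step is a 1.1-fold lower number from compound 2 to compound 3 (0.04 log units; within the scatter). For compound 3 the estimated value is 15000 nM, with an expected range from 8000 nM to 28000 nM.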

Compound 3, half-maximal inhibitory concentration: 18200 nM
Estimate against measurement, compound 3: 1.2-fold (0.08 log units) below, within the range that was stated.
By their numbers in this assay, from the lowest: compounds 2, 3 and 1 (each within the scatter of the next).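

In this assay the added chain carbon, on a saturated chain carbon, three bonds along the chain from a carbonyl carbon, gives a 1.1-fold higher number from compound 2 to compound 3 (0.05 log units; within the scatter) and so again leaves the number level. The comparison of the two ends of the series gives a 1.0-fold lower number from compound 1 to compound 3 (0.02 log units; within the scatter) and is also within the scatter, so the level result of the single earlier step now holds over all the chain lengths shown, and compound 1, compound 2 and compound 3 cannot be ranked against one another. No measurement at hand accounts for this level result.

From the compounds shown here alone, whether a longer chain would stay level with these compounds remains open, as does the effect of an amine or a carboxylic acid in place of the sulfur-bearing group. The compounds shown also share one core and one read-out, so whether a change on that core would give a step beyond the scatter, and whether the level result carries over to any other assay, remain unanswered.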